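Amide chain isomers on a trimethoxyphenyl benzylamide series

A few compounds are considered here, and "the series" means these few. Any claim that something is new, unique, unknown or untested is made for them only; others in the source may bear on it.

Two compounds have numbers in a functional assay on HCT-116 cells (Homo sapiens) for inhibition, read by MTT assay, with a stated time of 48 h (on this read-out lower numbers stand for stronger inhibition and higher numbers for weaker inhibition), so far. Compound 1 `COc1ccc(CN(C(=O)C=C(C)C)c2cc(OC)c(OC)c(OC)c2)cc1O` gives 290 nM and stands lowest of the two; compound 2 `COC(=O)c1cc(CNc2cc(OC)c(OC)c(OC)c2)ccc1OC` gives 38100 nM, a much higher number that lies beyond the usual scatter. Compound 3 `CC/C=C/C(=O)N(Cc1ccc(OC)c(O)c1)c1cc(OC)c(OC)c(OC)c1` shares all atoms with compound 1, joined differently: but-1-en-1-yl in place of 2-methylprop-1-en-1-yl on a carbonyl carbon. Nothing measured yet shows how such a rearrangement of the acyl chain reads out here, so the step is expected to be small and uncertain in direction, a 1.4-fold higher number from compound 1 to compound 3 (0.14 log units; within the scatter). Compound 3 is therefore expected to give about 400 nM, with a range from 150 nM to 1200 nM.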

Compound 3, half-maximal inhibitory concentration: 63 nM
The estimate for compound 3 lay 6.3-fold (0.80 log units) above the measured number; the whole stated range lies above it.
By their numbers in this assay, from the lowest: compound 3; then compound 1; then compound 2.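

The acyl chain on the carbonyl carbon is a sensitive position in this assay: with the atoms unchanged, but-1-en-1-yl in place of 2-methylprop-1-en-1-yl gives a step beyond the scatter (a 4.6-fold lower number from compound 1 to compound 3 (0.66 log units; beyond the scatter)). Rearranging this chain alone therefore moves the number, with the straight-chain isomer lower. No available evidence bears on the reason for this step.

This single pair cannot show how far the trend extends. Going by these compounds, whether a saturated butyl chain, a longer pent-1-en-1-yl chain or a terminal carboxylic acid would keep the lower number remains open.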